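Trimming the sulfonamide chain in a weak growth inhibitor

This account rests on a few compounds, and the source may have more. Where it says the series, first, only, none or still open, it means among the compounds named here.

Compound 1 `CCC1C(=O)N(C)c2cnc(Nc3ccc(S(=O)(=O)NCC(C)C)cc3)nc2N1c1ccn(C)n1`: 31600 nM
Compound 2 `CCC1C(=O)N(C)c2cnc(-n3ccc4cc(C(=O)NC(C)C)ccc43)nc2N1c1ccn(C)n1`: 22000 nM
Compound 3 `CC[C@@H]1C(=O)N(C)c2cnc(-n3ccc4cc(C(=O)NC)ccc43)nc2N1C1CCCC1`: 2200 nM

All three were tested in a functional assay on A549 cells (Homo sapiens) for antiproliferative activity, read by CCK-8 assay, with a stated time of 72 h; a higher number here means a weaker inhibitor of growth, a lower number a stronger inhibitor of growth. Compound 1 sits at the high end of these numbers: compound 2 gives a number within the scatter of it, while compound 3 gives a far lower number, a gap beyond the scatter. Compound 4 `CCC1C(=O)N(C)c2cnc(Nc3ccc(S(=O)(=O)NC)cc3)nc2N1c1ccn(C)n1` differs from compound 1 in one place: hydrogen in place of isopropyl on a saturated chain carbon bound to a sulfonamide nitrogen. Within the data shown here, no measured pair shows this same change, so its effect cannot be read from the data. The step of a 1.1-fold higher number from compound 1 to compound 4 (0.04 log units; within the scatter) is expected to stay within the scatter, in no clear direction. Compound 4 is therefore expected to give about 35000 nM, with a range from 12000 nM to 100000 nM.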

Compound 4, concentration for 50% growth inhibition: 12600 nM
Compound 4: the middle estimate sits 2.8-fold (0.44 log units) above what was measured, and the stated range covers the measured number.
By their numbers in this assay, from the lowest: compound 3; then compounds 4, 2 and 1 (each within the scatter of the next, the first and the last beyond it).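

Changing isobutylsulfamoyl to methylsulfamoyl gives a 2.5-fold lower number from compound 1 to compound 4 (0.40 log units; beyond the scatter) in this assay. This single pair shows that the group at this place affects growth inhibition, and that the isobutyl chain is not needed for the activity seen here: the shorter methyl group does modestly better. Nothing measured here explains why the number falls.

As far as these compounds go, it remains open whether an ethyl group would fall between these two compounds, or how a chain ending in an amine or a carboxylic acid would behave at this place.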